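The compounds below may be only part of what the source reports. "The series", "measured", "known", "first", "only" and "open" are said of these compounds alone.

Measured so far:
Compound 1 `COc1ccc2[nH]cc(/C=C(\C#N)C(=O)c3c[nH]c4ccccc34)c2c1` gives 30500 nM in a functional assay on PC-3 cells (Homo sapiens) for cytotoxicity, read by WST assay, with a stated time of 48 h; on this read-out higher numbers stand for weaker inhibition and lower numbers for stronger inhibition.
Compound 2 `N#C/C(=C\c1c[nH]c2cc(F)ccc12)C(=O)c1c[nH]c2cc(F)ccc12` gives > 50000 nM in this assay; that is a limit of the assay, not a number.

Compound 1 therefore carries the only actual number shown, while the other result is a limit, (the limit of > 50000 nM in this assay, at which 1 of the 2 values shown sits). Compound 3 `COc1ccc2c(C(=O)/C(C#N)=C/c3c[nH]c4ccc(OC)cc34)c[nH]c2c1` differs from compound 1 by methoxy in place of hydrogen on an aromatic carbon. Within the data shown here, no step between two measured compounds is available here, so this change has not been tested directly, and its effect is unknown. The step of a 1.1-fold higher number from compound 1 to compound 3 (0.06 log units; within the scatter) is expected to be small, within the usual scatter. Compound 3 is estimated at 35000 nM, with a likely range from 12000 nM to 100000 nM.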

Compound 3, half-maximal inhibitory concentration: 37100 nM
Compound 3: middle estimate off by 1.1-fold (0.03 log units), on the low side; measured number inside the range.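

Methoxy in place of hydrogen on this aromatic carbon gives a 1.2-fold higher number from compound 1 to compound 3 (0.09 log units; within the scatter) in this assay. Among these compounds, this is the first direct reading of a change at this position, and it shows that adding methoxy here leaves the two compounds indistinguishable on this read-out. Nothing shown gives a reason for this result.

Still open, going by these compounds, is whether an amine or a carboxylic acid on this same aromatic carbon would shift the number beyond the scatter. This single step also says nothing about changes elsewhere on the core of compound 1.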